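Removing a chloro group on two linker lengths

A few compounds are considered here, and "the series" means these few. Any claim that something is new, unique, unknown or untested is made for them only; others in the source may bear on it.

Measured so far in a functional assay on the whole organism with Mus musculus as the target; on this read-out higher numbers stand for an effect only at larger amounts of compound and lower numbers for an effect already at smaller amounts:
compound 1 `O=c1oc2cccnc2n1CN1CCN(c2ccccc2)CC1` gives 5.9 mg/kg
compound 2 `O=c1oc2cccnc2n1CN1CCN(c2ccccc2Cl)CC1` gives 22.2 mg/kg
compound 3 `O=c1oc2cccnc2n1CCN1CCN(c2ccc(Cl)cc2)CC1` shows only a limit, > 50 mg/kg

The value for compound 3 is a limit of this assay, not a number, and the limit of > 50 mg/kg in this assay, at which 1 of the 3 values shown sits, marks where it stands. Compound 4 `O=c1oc2cccnc2n1CCN1CCN(c2ccccc2)CC1` has not yet been measured in this assay.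

Compound 2 and compound 1 differ by hydrogen in place of chloro on an aromatic carbon, and the measured step is a 3.8-fold lower number from compound 2 to compound 1 (0.58 log units; beyond the scatter). Compound 3 and compound 4 differ by hydrogen in place of chloro on an aromatic carbon. The two places are not the same word for word: in compound 2 the chloro is ortho to a large group, in compound 3 it is para to a large group, so this is the same kind of change, not the same change. How the core of compound 3 differs from the core of compound 2 is not broken down here.

Compound 4 is expected to give about 30 mg/kg, with a range from 8 mg/kg to 100 mg/kg. The expected step is an at least 1.6-fold lower number from compound 3 to compound 4 (0.22 log units; that floor lies within the scatter), which rests on the measured step of a 3.8-fold lower number from compound 2 to compound 1 (0.58 log units; beyond the scatter) and on the fact that compound 3 gave only a limit, so the starting point is itself uncertain.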

Compound 4, dose for half-maximal effect: 19.4 mg/kg
The estimate for compound 4 lay 1.5-fold (0.19 log units) above the measured number, within the range that was stated.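

In this assay, hydrogen in place of chloro again comes with a lower number, an at least 2.5-fold lower number from compound 3 to compound 4 (0.41 log units; beyond the scatter), so the change runs the same way on both cores, even though the chloro sits in a different place on each. This shows a shared direction for these two pairs only, and it does not show that the change carries over from one core to the other by the same amount: the same change on two cores in this assay, a 3.8-fold lower number (0.58 log units; beyond the scatter) from compound 2 to compound 1 and an at least 2.5-fold lower number (0.41 log units; beyond the scatter) from compound 3 to compound 4; the limit leaves it open whether they differ. As far as these compounds go, compound 3 has only a limit, not a number, so the full size of its step remains unknown: the limit of > 50 mg/kg in this assay, at which 1 of the 4 values shown sits.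

The compounds shown leave open whether a fluoro or a methoxy group in the position of the chloro would give a step in the same direction on either core. They also leave open whether the same change would still lower the number on a longer chain than the two linkers seen here.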